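The source may report more compounds than this note shows. Statements on the series, on what has been measured and on what is new or still open speak of the compounds shown alone.

Compound 1 `C[C@@H](O)[C@H]1C(=O)N2C(C(=O)OCOC(=O)OC(C)(C)C)=C(S[C@@H]3CN[C@H](C(=O)Nc4cccc(C(=O)O)c4)C3)[C@H](C)[C@H]12` in an ADME assay for metabolic stability, read by LC-MS, with a stated time of 3 h, at pH 6.5, tested at 50 uM (a lower number here means that less of the compound is left, a higher number that more of the compound is left), gives > 95%, which is a limit of the assay rather than a number. Compound 2 `C[C@@H](O)[C@H]1C(=O)N2C(C(=O)OCOC(=O)OC(C)(C)C)=C(S[C@@H]3CN[C@H](C(=O)Nc4cccc(C(=O)OCOC(=O)OC(C)(C)C)c4)C3)[C@H](C)[C@H]12` in this assay gives > 95%, likewise a limit. Among the compounds with values here, the one measured step, a step that the two limits leave unreadable from compound 1 to compound 2, therefore has no readable size, since the limit of > 95% in this assay, at which 2 of the 2 values shown sit, covers both values. Compound 3 `CC(C)OC(=O)C1=C(S[C@@H]2CN[C@H](C(=O)Nc3cccc(C(=O)O)c3)C2)[C@H](C)[C@@H]2[C@@H]([C@@H](C)O)C(=O)N12` differs from compound 1 by isopropyl in place of ((tert-butoxycarbonyl)oxy)methyl on an oxygen next to a carbonyl group, so the ester carrying the ((tert-butoxycarbonyl)oxy)methyl group becomes an isopropyl ester on the same oxygen next to a carbonyl group. Within the data shown here, no measured step bears on this change in a readable way; the only comparison in hand, between compound 1 and compound 2, sits wholly at the limit. Compound 3 is thus expected to remain at or near that limit, with a number no higher from compound 1 to compound 3 (the limit leaves the size open) estimated as a step of no readable size. The estimate for compound 3 is 95%, within 80% to 99%, and is expected to be reported as a limit.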

Compound 3, percent of the compound remaining: > 95%
Compound 3: a limit, no number; the forecaster's own chance of this, stated with the estimate: 75%; the middle value sits exactly at the limit.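

In this assay compound 3 gives > 95%, a limit, so nothing can be read between compound 1 and compound 3: the limit of > 95% in this assay, at which 3 of the 3 values shown sit. The compounds shown leave open whether isopropyl and ((tert-butoxycarbonyl)oxy)methyl on this oxygen differ at all in this assay.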